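The source may report more compounds than this note shows. Statements on the series, on what has been measured and on what is new or still open speak of the compounds shown alone.

Measured so far, in a functional assay on HEK293 cells for positive allosteric modulation of metabotropic glutamate receptor 5 (Homo sapiens), read by calcium flux; on this read-out higher numbers stand for larger maximal responses and lower numbers for smaller maximal responses:
compound 1 `O=C1c2cc(COc3ccc(F)cc3)nn2CCN1c1ccc(F)cc1`: 72%
compound 2 `Cc1ccc(OCc2cc3n(n2)CCN(c2ccc(F)cc2)C3=O)cc1`: 58%

Compound 2 has the lower of the two numbers; the step of a number 14 percentage points lower from compound 1 to compound 2 (beyond the scatter) separates it from compound 1. Compound 3 `O=C1c2cc(COc3ccccn3)nn2CCN1c1ccc(F)cc1` differs from compound 2 by pyridin-2-yl in place of 4-methylphenyl on an oxygen on a saturated carbon. Among the measured compounds shown here, no measured step covers this exact exchange. For the measured compounds named here, the only step that touches the same ring, a number 14 percentage points lower from compound 1 to compound 2 (beyond the scatter), shows that altering this ring can shift the maximal response by a modest amount. A modest shift of similar size is therefore expected, with the direction uncertain. The estimate for compound 3 is 64%, within 44% to 84%, which would mean an expected step of a number 6 percentage points higher from compound 2 to compound 3 (within the scatter).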

Compound 3, largest response reached (Emax), in percent of the reference or control that the assay uses: 68%
The estimate for compound 3 lay 4 percentage points below the measured number, and the stated range covers the measured number.
By their numbers in this assay, from the lowest: compounds 2, 3 and 1 (each within the scatter of the next, the first and the last beyond it).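

With pyridin-2-yl on this oxygen, a ring holding a nitrogen and a hydrogen-bond acceptor takes the place of an all-carbon ring, and in this assay the two steps that show this stay within the scatter (a number 10 percentage points higher from compound 2 to compound 3 (within the scatter); a number 4 percentage points lower from compound 1 to compound 3 (within the scatter)). The maximal response of compound 3 therefore cannot be told apart from that of either compound 1 or compound 2, although those two differ beyond the scatter. Nothing measured here explains this result.

Still open, going by these compounds, is whether a pyridin-3-yl or pyrimidin-2-yl ring at this position would give a similar maximal response.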